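Dimethylation of the carbamoyl amide in compound 3

This account rests on a few compounds, and the source may have more. Where it says the series, first, only, none or still open, it means among the compounds named here.

Compound 1 `CO[C@H]1CC[C@@H](Nc2cc(NCc3cnccc3C(F)(F)F)ncc2C#N)CC1` gives 5000 nM in an assay on isolated protein for inhibition of protein kinase C delta type (Homo sapiens), read by TR-FRET, with a stated time of 2 h; on this read-out higher numbers stand for weaker inhibition and lower numbers for stronger inhibition. Compound 2 `CO[C@H]1CC[C@H](CNc2cc(NCc3cnccc3C(F)(F)F)ncc2C#N)CC1` reaches only a limit of the assay, > 10000 nM, in this assay. Compound 3 `N#Cc1cnc(NCc2cnccc2C(F)(F)F)cc1N[C@H]1CC[C@@H](C(N)=O)CC1` gives 400 nM in this assay, the lowest of the two numbers recorded; the nearest is compound 1, with a 13-fold lower number from compound 1 to compound 3 (1.10 log units; beyond the scatter). The other steps read an at least 2.0-fold higher number from compound 1 to compound 2 (0.30 log units; that floor lies within the scatter) and an at least 25-fold lower number from compound 2 to compound 3 (1.39 log units; beyond the scatter); one value sits at the limit of > 10000 nM in this assay, at which 1 of the 3 values shown sits.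

Compound 4 `CN(C)C(=O)[C@H]1CC[C@@H](Nc2cc(NCc3cnccc3C(F)(F)F)ncc2C#N)CC1` differs from compound 3 by dimethylamino in place of amino on a carbonyl carbon, that is, carbamoyl to dimethylcarbamoyl. For the measured compounds named here, no measured step alters the carbamoyl itself; the only step touching that ring position is the exchange of methoxy for carbamoyl, which gave a 13-fold lower number from compound 1 to compound 3 (1.10 log units; beyond the scatter). Removing the amide hydrogen from compound 3 is therefore expected to give back part of that gap, a moderate rise in this assay of about a 3.8-fold higher number from compound 3 to compound 4 (0.57 log units; beyond the scatter). Compound 4 is estimated at 1500 nM, with a range from 400 nM to 6000 nM.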

Compound 4, half-maximal inhibitory concentration: 1800 nM
Beside the measured number, compound 4's estimate is 1.2-fold (0.08 log units) below it; measured number inside the range.
By their numbers in this assay, from the lowest: compound 3; then compound 4; then compound 1. At a limit, above all of these: compound 2.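

On the carbamoyl at this saturated ring carbon, the amide nitrogen does not accept dimethylamino in place of amino without cost: in this assay the change gives a 4.5-fold higher number from compound 3 to compound 4 (0.65 log units; beyond the scatter) and removes the hydrogen-bond donor counted for amino. The gain over methoxy is reduced but not lost, with a 2.8-fold lower number from compound 1 to compound 4 (0.44 log units; beyond the scatter) showing that dimethylcarbamoyl still keeps part of the advantage seen for carbamoyl. Nothing at hand gives a measured basis for a cause of either step.

The compounds shown do not separate the loss of the amide hydrogens from the added methyl groups, a question that the single-methyl amide, methylcarbamoyl, would address. Also open, as far as these compounds go, is whether other carbonyl groups at this ring carbon, such as a carboxylic acid or a pyrrolidine amide, follow carbamoyl or dimethylcarbamoyl.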